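A few compounds are considered here, and "the series" means these few. Any claim that something is new, unique, unknown or untested is made for them only; others in the source may bear on it.

Working notes on the series. The shared core appears in compound 1 `CSc1ccc(NC(=O)Nc2cc(C)nc3ccccc23)cc1`, which in an ADME assay on HEK293 cells (Homo sapiens) for cytotoxicity, with a stated time of 72 h (a lower number here means that less compound is needed, a higher number that more compound is needed for the effect), gives 24000 nM. Compound 3 `COC(=O)c1cccc(NC(=O)Nc2cc(C)nc3ccccc23)c1` carries a different substituent on the aryl urea partner; in this assay compound 3 gives 26000 nM, a value within the scatter of that of compound 1. Compound 2 `Cc1cc(NC(=O)Nc2cnc3ccccc3c2)c2ccccc2n1` gives > 25000 nM, which is a limit of this assay rather than a number. Of the two numbers reported, compound 1 holds the lower one, with compound 3 nearest; the gap between them lies within the scatter, so no order is read from it. One of the three values is a limit (the limit of > 25000 nM in this assay, at which 1 of the 3 values shown sits), and the two numbers sit close to it.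

Compound 4 `Cc1cc(NC(=O)Nc2ccc(SC(F)(F)F)cc2)c2ccccc2n1` is not yet measured in this assay. It differs from compound 1 in one place: trifluoromethyl in place of methyl on a sulfur. No step between two measured compounds of this set carries the same change, so nothing shown bears directly on it. The measured values, two numbers within the scatter of one another and one limit, all lie in one narrow region, and the change from methylsulfanyl to (trifluoromethyl)sulfanyl has no shown ground for a move away from it. The step from compound 1 to compound 4 in this assay is expected to be no change at the digits printed from compound 1 to compound 4 (within the scatter), none beyond the scatter. For compound 4 the expected value in this assay is 24000 nM, with a range from 12000 nM to 50000 nM, and a fair chance that only a limit is reported.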

Compound 4, half-maximal effective concentration: 13000 nM
The estimate for compound 4 lay 1.8-fold (0.27 log units) above the measured number; low and high end bracket the measured number.
By their numbers in this assay, from the lowest: compounds 4, 1 and 3 (each within the scatter of the next).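

Going by these compounds alone, on the sulfur whose other neighbour is an aromatic carbon, trifluoromethyl in place of methyl gives the only step that can be read so far: in this assay the exchange gives a 1.8-fold lower number from compound 1 to compound 4 (0.27 log units; within the scatter). Within the data shown here, until now, the opening compounds offered no step between two measured compounds, so this is the first direct reading of any single change, and it shows that replacing methylsulfanyl with (trifluoromethyl)sulfanyl produces no difference beyond the scatter. Compound 2 remains a limit rather than a number and adds no step to this reading: the limit of > 25000 nM in this assay, at which 1 of the 4 values shown sits.

The compounds shown leave open whether any other group at this place would give a step beyond the scatter, such as a longer chain like ethyl on the sulfur, or an amine or a carboxylic acid in place of the whole methylsulfanyl group. On these data alone, with a single step at this position, it also remains open whether the same exchange would give a comparable result on the aryl urea partner of another compound.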